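Vinyl in place of nitro on the aryl ring

The source may hold more compounds than are shown below. What is called first, only, known or untested is meant among the compounds shown, and "the series" means these compounds.

Compound 2 `C/C(=C\c1cc(-c2ccc([N+](=O)[O-])cc2)cs1)C(N)=O` gives 1210 nM in a functional assay on MCF7 cells (Homo sapiens) for cytotoxicity, read by CCK-8 assay, with a stated time of 24 h (on this read-out higher numbers stand for weaker inhibition and lower numbers for stronger inhibition), the lowest of the two numbers; its nearest neighbour, compound 1 `C/C(=C\c1cc(-c2ccccc2)cs1)C(N)=O`, gives 2680 nM in this assay. Compound 3 `C=Cc1ccc(-c2csc(/C=C(\C)C(N)=O)c2)cc1` differs from compound 2 by vinyl in place of nitro on an aromatic carbon. Among the measured compounds shown here, the only step that bears on this is a 2.2-fold lower number from compound 1 to compound 2 (0.35 log units; beyond the scatter), which removes the same group in the reverse direction but arrives at hydrogen rather than vinyl. Compound 3 is therefore expected to sit between the two measured numbers, a step of a 1.7-fold higher number from compound 2 to compound 3 (0.22 log units; within the scatter) that may not exceed the scatter. Compound 3 is estimated at 2000 nM, within 900 nM to 4500 nM.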

Compound 3, half-maximal inhibitory concentration: > 50000 nM
Compound 3 ended at the assay's limit; the forecaster's own chance of this, stated with the estimate: 3%; middle value at least 25-fold (1.39 log units) away from the limit.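

In this assay compound 3 stands at a limit of the assay, not at a number: the limit of > 50000 nM in this assay, at which 1 of the 3 values shown sits.

At this position, para to a large group, a single change can do far more than a 2.2-fold lower number from compound 1 to compound 2 (0.35 log units; beyond the scatter) suggested: vinyl gives an at least 41-fold higher number from compound 2 to compound 3 (1.61 log units; beyond the scatter), and set against hydrogen it gives an at least 18-fold higher number from compound 1 to compound 3 (1.27 log units; beyond the scatter). Loss of nitro alone does not reproduce this: compound 1, with hydrogen there, gives 2680 nM.

The compounds shown do not tell why vinyl differs from hydrogen and nitro. They also leave open whether an amine, a carboxylic acid or an ethyl group at this position would follow vinyl or nitro.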